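Notes on the step from compound 1 to compound 3

The compounds below may be only part of what the source reports. "The series", "measured", "known", "first", "only" and "open" are said of these compounds alone.

Going by the values given here, compound 1 `COc1ccc(/C=N/NC(=S)NC(C)(C)[C@H]2CC=C(C)CC2)cc1` is the only member of the series with a number in a functional assay on MCF7 cells (Homo sapiens) for inhibition, read by sulforhodamine B assay, with a stated time of 48 h; a lower number here means a stronger inhibitor of growth, a higher number a weaker inhibitor of growth; in this assay compound 1 gives 31200 nM. Compound 2 `CC1=CC[C@H](C(C)(C)NC(=S)N/N=C/c2cccc([N+](=O)[O-])c2)CC1` is reported in this assay only as a limit of the assay, > 100000 nM. Beyond the single number, what is shown is the limit of > 100000 nM in this assay, at which 1 of the 2 values shown sits. Among the compounds with values here, no two measured compounds differ in a single place, so no measured step is available to set the scale. Compound 3 `CC1=CC[C@H](C(C)(C)NC(=S)N/N=C/c2ccc[nH]2)CC1` carries the change (1H-pyrrol-2-yl in place of 4-methoxyphenyl on a carbon with a double bond to nitrogen), that is 1H-pyrrol-2-yl in place of 4-methoxyphenyl on a carbon with a double bond to nitrogen. Within the data shown here, with no measured step to guide direction, the step in this assay is expected to be small, within the scatter or slightly toward weaker growth inhibition, a 1.3-fold higher number from compound 1 to compound 3 (0.11 log units; within the scatter). For compound 3 the estimate in this assay is 40000 nM, expected between 12000 nM and 130000 nM, with a real chance that only a limit is reported.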

Compound 3, concentration for 50% growth inhibition: 3900 nM
Compound 3: middle estimate off by 10-fold (1.01 log units), on the high side; the whole stated range lies above it.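

Going by these compounds alone, the place on a carbon with a double bond to nitrogen is sensitive to the group it carries in this assay: 1H-pyrrol-2-yl in place of 4-methoxyphenyl gives an 8.0-fold lower number from compound 1 to compound 3 (0.90 log units; beyond the scatter) and is the first step that can be read. The change replaces a six-membered aromatic ring of carbon only with a five-membered aromatic ring with 1 hetero atom, and it also brings in 1 hydrogen-bond donor, so this single step cannot separate ring size from the donor. No measured property shown here accounts for the step.

A furan-2-yl or 1-methyl-1H-pyrrol-2-yl group at this place would test whether the hydrogen on the pyrrole nitrogen matters. From the compounds shown here alone, how a phenyl ring carrying an amine would read in this assay also remains open.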